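The source may hold more compounds than are shown below. What is called first, only, known or untested is meant among the compounds shown, and "the series" means these compounds.

The piece opens with compound 1 `Cn1cccc1-c1cc(-c2cccs2)nc(N)c1C#N`, which carries a thiophen-2-yl group on its shared core. In a functional assay on SF-268 cells (Homo sapiens) for inhibition, read by sulforhodamine B assay, with a stated time of 48 h (on this read-out higher numbers stand for weaker inhibition of growth and lower numbers for stronger inhibition of growth), compound 1 gives only a limit of the assay, > 100000 nM. Compound 2 `Cn1cccc1-c1cc(-c2cccs2)[nH]c(=O)c1C#N`, the related compound with a ring carbonyl in place of the amino group, also reaches only a limit in this assay, > 100000 nM. Two of the three values shown sit at this boundary (the limit of > 100000 nM in this assay, at which 2 of the 3 values shown sit). Compound 3 `COc1ccc(-c2cc(-c3cccn3C)c(C#N)c(N)n2)cc1OC`, bearing a dimethoxyphenyl group, gives 83200 nM in this assay, a number rather than a limit. The unmeasured compound 4 `Cn1cccc1-c1cc(-c2ccccc2)nc(N)c1C#N` differs from compound 1 by phenyl in place of thiophen-2-yl on an aromatic carbon. Within the data shown here, with compound 1 known only as a limit, no measured step can be sized. A change from compound 1 to compound 4 of a number no higher from compound 1 to compound 4 (the limit leaves the size open) is expected, within the scatter. For compound 4 the estimate is 100000 nM, between 40000 nM and 300000 nM.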

Compound 4, concentration for 50% growth inhibition: 79400 nM
Compound 4: middle estimate off by 1.3-fold (0.10 log units), on the high side; low and high end bracket the measured number.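

Phenyl in place of thiophen-2-yl on this aromatic carbon, next to the ring nitrogen, gives the only step at this position that can be bounded: in this assay there is an at least 1.2-fold lower number from compound 1 to compound 4 (0.10 log units; that floor lies within the scatter). With phenyl here, the read-out is a number rather than a limit. The true size of the step stays unknown because only a limit is available for compound 1: the limit of > 100000 nM in this assay, at which 2 of the 4 values shown sit.

The compounds shown leave open how far the step extends beyond that floor. They also leave open how a carboxylic acid or a cyclohexyl group on this carbon would read.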